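Swapping a Fluorinated Ring for a Second Ester Arm

The source may report more compounds than this note shows. Statements on the series, on what has been measured and on what is new or still open speak of the compounds shown alone.

Compound 1 `COC(=O)/C=C/c1cccc(N(Cc2ccc(/C=C/c3c(Cl)cccc3Cl)cc2)C(=O)C(C)C)c1`: 195 nM
Compound 2 `COC(=O)/C=C/c1cccc(N(Cc2ccc(-c3ccc(F)c(F)c3)cc2)C(=O)C2CCCCC2)c1`: 72 nM
Compound 3 `COC/C=C/c1cccc(N(Cc2ccc(/C=C/C(=O)OC(C)(C)C)cc2)C(=O)C2CCCCC2)c1`: 243 nM

All three were tested in an assay on isolated protein with Bile acid receptor (Homo sapiens) as the target; on this read-out higher numbers stand for an effect only at larger amounts of compound and lower numbers for an effect already at smaller amounts. Compound 2 gives the lowest number of the three, and both other compounds lie beyond the usual scatter above it, compound 3 furthest. Compound 4 `COC(=O)/C=C/c1ccc(CN(C(=O)C2CCCCC2)c2cccc(/C=C/C(=O)OC)c2)cc1` has not yet been measured. It differs from compound 2 in one place: 2-(methoxycarbonyl)ethenyl in place of 3,4-difluorophenyl on an aromatic carbon. Among the compounds with values here, no measured pair isolates exactly this change. Still, compound 3 also carries an ester-bearing ethenyl arm on that aromatic carbon rather than a second aromatic ring, and gives a weaker number, so a step toward a higher number is expected for compound 4 because compound 3 gives 243 nM, namely a 2.8-fold higher number from compound 2 to compound 4 (0.44 log units; beyond the scatter). Compound 4 is therefore estimated at 200 nM, within 70 nM to 600 nM.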

Compound 4, half-maximal effective concentration: > 1000 nM
Compound 4 ended at the assay's limit; the forecaster's own chance of this, stated with the estimate: 5%; middle value at least 5.0-fold (0.69 log units) from the limit.
By their numbers in this assay, from the lowest: compound 2; then compounds 1 and 3 (each within the scatter of the next). At a limit, above all of these: compound 4.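

This is the first change shown that touches only this aromatic carbon, and its effect is large: 2-(methoxycarbonyl)ethenyl in place of 3,4-difluorophenyl gives an at least 13-fold higher number from compound 2 to compound 4 (1.14 log units; beyond the scatter). On the shared core, then, the ring and the ester arm are not interchangeable at this position. Compound 4 stands at a limit of the assay, not at an exact number: the limit of > 1000 nM in this assay, at which 1 of the 4 values shown sits.

These compounds cannot separate losing the ring from gaining the ester. From the compounds shown here alone, how an unsubstituted phenyl ring, or a carboxylic acid in place of the methyl ester, would behave at this carbon remains open.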